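A few compounds are considered here, and "the series" means these few. Any claim that something is new, unique, unknown or untested is made for them only; others in the source may bear on it.

Measured compounds:
compound 1, `CNC(=O)Nc1nc2ccc(-c3cnc(OC)c(NS(=O)(=O)c4ccc(F)cc4)c3)cc2s1`, 1560 nM
compound 2, `CCN(CC)CCNC(=O)Nc1nc2ccc(-c3cnc(OC)c(NS(=O)(=O)c4ccc(C)cc4)c3)cc2s1`, 310 nM

Both numbers come from a functional assay on A549 cells (Homo sapiens) for antiproliferative activity, read by MTT assay, with a stated time of 72 h; a lower number here means a stronger inhibitor, a higher number a weaker inhibitor. Of the two, compound 1 stands at the higher number, and the gap to compound 2 is beyond the usual scatter of this kind of measurement. Compound 2 differs from compound 1 in more than one place, so the two values alone show that the pair with the longer amine-bearing chain gives the lower number, without telling which change carries it.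

Compound 3, `COc1ncc(-c2ccc3nc(NC(=O)NCCN(C)C)sc3c2)cc1NS(=O)(=O)c1ccc(F)cc1`, has not yet been measured in this assay. It differs from compound 1 in a single way: (dimethylamino)methyl in place of hydrogen on a saturated chain carbon bound to an amide-type nitrogen. The change places a basic amine-bearing chain on the urea end, a feature that compound 2 also carries. The expectation is therefore a lower number than compound 1, with a step of a 3.5-fold lower number from compound 1 to compound 3 (0.54 log units; beyond the scatter) beyond the scatter. Compound 3 is estimated at 450 nM, within a range from 150 nM to 1300 nM.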

Compound 3, half-maximal inhibitory concentration: 470 nM
The estimate for compound 3 lay 1.0-fold (0.02 log units) below the measured number; measured number inside the range.
By their numbers in this assay, from the lowest: compounds 2 and 3 (each within the scatter of the next); then compound 1.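

In this assay, replacing the methyl of the methylcarbamoyl end with 2-(dimethylamino)ethyl gives a 3.3-fold lower number from compound 1 to compound 3 (0.52 log units; beyond the scatter), a modest step. Compound 1 and compound 2 differ in more than one place, so they could not tie a lower number to any single change; this pair shows that this position responds to this one change with the rest of the molecule held fixed. The data shown offer no measurement that explains the step.

On these data alone, it remains open whether the step belongs to the amine nitrogen or simply to the longer chain, a question that a plain butyl chain at this position would address. Also open, as far as these compounds go, is how a cyclic amine such as morpholine, or a carboxylic acid at the chain end, would compare with the (dimethylamino)methyl group.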